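A few compounds are considered here, and "the series" means these few. Any claim that something is new, unique, unknown or untested is made for them only; others in the source may bear on it.

Working notes on the series, with two compounds measured so far. In a functional assay on CWR22R cells (Homo sapiens) for antiproliferative activity, read by propidium iodide staining, with a stated time of 96 h (a lower number here means a stronger inhibitor, a higher number a weaker inhibitor), compound 1 (`CC(O)(COc1cccc(S(F)(F)(F)(F)F)c1)C(=O)Nc1cccc(S(F)(F)(F)(F)F)c1`) gives 27300 nM. In this assay compound 2 (`CC(O)(COc1cccc(C(F)(F)F)c1)C(=O)Nc1cccc(S(F)(F)(F)(F)F)c1`) gives 28900 nM, which places compound 2 level with compound 1 within the scatter, so the two numbers cannot be ranked.

Compound 3 (`CC(O)(COc1cccc(OC(F)(F)F)c1)C(=O)Nc1cccc(S(F)(F)(F)(F)F)c1`) has not yet been measured. It carries trifluoromethoxy in place of trifluoromethyl on an aromatic carbon, meta to a large group: trifluoromethoxy in place of trifluoromethyl on an aromatic carbon.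

Going by the values given here, one measured step bears on this change, as it exchanges the group on the same aromatic carbon: a 1.1-fold higher number from compound 1 to compound 2 (0.02 log units; within the scatter). That exchange stayed within the scatter. Among the compounds with values here, it is still a single step, and no measured compound carries trifluoromethoxy, so the evidence is thin. No step beyond the scatter is therefore expected in this assay.

The expected step is a 1.0-fold lower number from compound 2 to compound 3 (0.01 log units; within the scatter). For compound 3 the estimated value is 28000 nM, with an expected range from 14000 nM to 55000 nM.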

Compound 3, half-maximal inhibitory concentration: 18800 nM
Beside the measured number, compound 3's estimate is 1.5-fold (0.17 log units) above it; the range from low to high includes it.
By their numbers in this assay, from the lowest: compounds 3, 1 and 2 (each within the scatter of the next).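

In this assay, a third group on this aromatic carbon again gives no step beyond the scatter: a 1.5-fold lower number from compound 2 to compound 3 (0.19 log units; within the scatter), and a 1.5-fold lower number from compound 1 to compound 3 (0.16 log units; within the scatter). The tolerance seen so far therefore extends from a single exchange to three groups that cannot be ranked, and the oxygen and hydrogen-bond acceptor that enter with trifluoromethoxy bring no readable change, although all three groups are fluorinated and the rest of the core is unchanged. No measurement at hand speaks to what lies behind these numbers.

The compounds shown leave open whether a group without fluorine on this carbon, such as an amine, a carboxylic acid or a plain methyl, would give a step beyond the scatter, or whether the number would hold there as well. They also leave open whether trifluoromethoxy would behave in the same way on the other aromatic ring, where all three compounds carry the same sulfur-bearing group, so the flat result so far applies to this one position alone.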